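The source may hold more compounds than are shown below. What is called first, only, known or untested is meant among the compounds shown, and "the series" means these compounds.

Measured compounds:
compound 1, `Cc1sc2nc(-c3ccccn3)c(/C=N/NC(=N)N)n2c1C`, 37200 nM
compound 2, `N=C(N)N/N=C/c1c(-c2ccncc2)nc2sc(Cl)cn12`, 17000 nM
compound 3, `Cc1cn2c(/C=N/NC(=N)N)c(-c3cccnc3)nc2s1`, 36300 nM

In a functional assay on NSCLC cells (Homo sapiens) for antiproliferative activity (a higher number here means a weaker inhibitor of growth, a lower number a stronger inhibitor of growth), three compounds sharing the same fused core have been measured. Compound 3 stands second highest of the three numbers. Its nearest neighbour is compound 1, whose value in this assay lies within the scatter of that of compound 3, so the two cannot be told apart. The furthest is compound 2, whose number in this assay is lower by a margin beyond the scatter, making it the stronger inhibitor of growth among the pair.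

Compound 4, `Cc1cn2c(/C=N/NC(=N)N)c(-c3ccncc3)nc2s1`, has not yet been measured in this assay. It differs from compound 3 in one place: pyridin-4-yl in place of pyridin-3-yl on an aromatic carbon. Going by the values given here, compound 2 also carries a pyridin-4-yl group, though on a differently substituted core, so no direct step to compound 4 is available from the compounds in hand.

Given the lower value of compound 2 with 17000 nM, a modest move of compound 4 toward a stronger inhibition of growth is expected, though one that may still fall within the scatter. The step of a 1.5-fold lower number from compound 3 to compound 4 (0.16 log units; within the scatter) is therefore expected to be small and downward. For compound 4 the estimated value in this assay is 25000 nM, with a range from 10000 nM to 60000 nM.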

Compound 4, concentration for total growth inhibition: 33100 nM
Compound 4: middle estimate off by 1.3-fold (0.12 log units), on the low side, and the stated range covers the measured number.
By their numbers in this assay, from the lowest: compounds 2, 4, 3 and 1 (each within the scatter of the next, the first and the last beyond it).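

In this assay, the exchange of pyridin-3-yl for pyridin-4-yl on this aromatic carbon gives a 1.1-fold lower number from compound 3 to compound 4 (0.04 log units; within the scatter) and so lies within the scatter, which means that on this core the two pyridines cannot be told apart at this position. Going by these compounds alone, the second comparison opens a different site on the core, where methyl in place of chloro on an aromatic carbon gives a 1.9-fold higher number from compound 2 to compound 4 (0.29 log units; within the scatter) and also stays within the scatter, so neither of the first two single changes that can be read separates its pair, and all of these numbers remain high in the range of values shown. No measurement offered alongside these numbers bears on why either change leaves the read-out where it is.

As far as these compounds go, whether a phenyl ring without any ring nitrogen, or a pyridine carrying an amine or a carboxylic acid, would hold the same level at the position next to the ring nitrogen remains open. From the compounds shown here alone, it is equally open whether an ethyl or methoxy group in place of the methyl of compound 4 would produce a step beyond the scatter.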